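A few compounds are considered here, and "the series" means these few. Any claim that something is new, unique, unknown or untested is made for them only; others in the source may bear on it.

Three compounds share one core and differ in the group attached to the far end of the piperazine ring. In an assay on HEK293 cells for inhibition of Voltage-dependent T-type calcium channel subunit alpha-1G (Homo sapiens), read by fluorescence, tested at 10 uM (on this read-out lower numbers stand for less inhibition and higher numbers for more inhibition at the one concentration tested (going by the name of the read-out)), compound 1 `CCCc1nc(-c2ccccc2)c(CNCCN2CCN(C(c3ccccc3)c3ccccc3)CC2)o1` gives 71.9%. Compound 2 `CCCc1nc(-c2ccccc2)c(CNCCN2CCN(c3cccc(C(F)(F)F)c3)CC2)o1` gives 56.3% in this assay, and compound 3 `CCCc1nc(-c2ccccc2)c(CNCCCN2CCN(c3ccc(C)cc3)CC2)o1` gives 53.9%. Compound 2 thus sits clearly below compound 1, a gap beyond the scatter, while its number and that of compound 3 lie within the scatter of each other, so no order between those two can be read from these data.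

Compound 4 `CCCc1nc(-c2ccccc2)c(CNCCN2CCN(c3ccccc3OC)CC2)o1` is not yet measured. It differs from compound 2 in one place: 2-methoxyphenyl in place of 3-(trifluoromethyl)phenyl on an amine nitrogen in a ring. Going by the values given here, no measured pair shows what this kind of swap does here, so nothing beyond the three numbers above supports a guess. The step of a number 4.3 percentage points lower from compound 2 to compound 4 (within the scatter) is expected to be small, if anything slightly downward, and not beyond the scatter. In this assay compound 4 is therefore estimated at 52%, with a range from 32% to 72%.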

Compound 4, a percentage reported as inhibition, at one concentration (the size of the read-out at that concentration, not a potency): 39.7%
The estimate for compound 4 lay 12.3 percentage points above the measured number; measured number inside the range.
By their numbers in this assay, from the lowest: compound 4; then compounds 3 and 2 (each within the scatter of the next); then compound 1.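

In this assay, going by these compounds alone, the change to 2-methoxyphenyl in place of 3-(trifluoromethyl)phenyl on the amine nitrogen in the ring gives a number 16.6 percentage points lower from compound 2 to compound 4 (beyond the scatter) and so provides the first direct comparison in which only one group differs. It shows that inhibition at the one concentration tested can respond to the choice of aryl group at this position, even though the entering and leaving groups both carry one six-membered aromatic ring of carbon only. Nothing measured here explains the change.

This single pair cannot separate the effect of exchanging trifluoromethyl for methoxy from the effect of their different ring positions. A 3-methoxyphenyl or a 2-(trifluoromethyl)phenyl group at the same nitrogen would address that question, and an unsubstituted phenyl group would provide a plain reference.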